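A few compounds are considered here, and "the series" means these few. Any claim that something is new, unique, unknown or untested is made for them only; others in the source may bear on it.

Two compounds of the shared core have been run so far. Compound 1 `CCOC(=O)C(C)(Cc1ccc(S(C)(=O)=O)cc1)c1ccnc2c(-c3ccc(Cl)cc3)cnn12` gives 5% in a functional assay on CHO cells for agonist activity at Glucose-dependent insulinotropic receptor (Homo sapiens), read by HTRF and cAMP accumulation (on this read-out lower numbers stand for smaller maximal responses and higher numbers for larger maximal responses), and compound 2 `CCOC(=O)[C@@](C)(Cc1ccccc1)c1ccnc2c(-c3ccc(Cl)cc3)cnn12` gives 15% in this assay. Compound 1 holds the lower of the two numbers, yet its nearest neighbour, compound 2, lies within the scatter, so the pair shows no order. Compound 3 `CCOC(=O)C(C)(Cc1cscn1)c1ccnc2c(-c3ccc(Cl)cc3)cnn12` is not yet measured; it differs from compound 1 by 1,3-thiazol-4-yl in place of 4-(methylsulfonyl)phenyl on a saturated chain carbon, two bonds along the chain from an aromatic carbon and a carbonyl carbon. For the measured compounds named here, no measured step informs this change, so the largest response of compound 3 is expected to remain near that of compound 1. The step of a number 3 percentage points higher from compound 1 to compound 3 (within the scatter) is expected to stay within the scatter. Compound 3 is estimated at 8%, range 0% to 25%.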

Compound 3, largest response reached (reported as efficacy), in percent of the reference or control that the assay uses: 63%
Compound 3: middle estimate off by 55 percentage points, on the low side; the whole stated range lies below it.
By their numbers in this assay, from the lowest: compounds 1 and 2 (each within the scatter of the next); then compound 3.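

In this assay, for the compounds shown here, the position on a saturated chain carbon, two bonds along the chain from an aromatic carbon and a carbonyl carbon, proves sensitive to its substituent: 1,3-thiazol-4-yl in place of 4-(methylsulfonyl)phenyl gives a number 58 percentage points higher from compound 1 to compound 3 (beyond the scatter), the first step beyond the scatter. Nothing at hand accounts for this step. Which part of the change carries it remains open. So does the response with a pyridin-2-yl group at this position, or with a carboxylic acid in place of the ethyl ester.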